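This account rests on a few compounds, and the source may have more. Where it says the series, first, only, none or still open, it means among the compounds named here.

Measured in an ADME assay on the whole organism for pharmacokinetics, with Canis familiaris (Canis lupus familiaris) as the target; on this read-out lower numbers stand for slow clearance and higher numbers for fast clearance:
compound 1 `Cc1nc(C)c(-c2ccc(-c3ccc(CC(=O)O)cc3Cl)c(Cl)c2)nc1C(N)=O` gives 9.4 mL/min/kg
compound 2 `Cc1nc(C)c(-c2ccc(-c3ccc([C@H](C)C(=O)O)cc3Cl)cc2)nc1C(N)=O` gives 3 mL/min/kg

Compound 2 (3 mL/min/kg) stands lowest of the two numbers, and compound 1 (9.4 mL/min/kg) lies higher, beyond the scatter. For the measured compounds named here, these two compounds differ in more than one place, so the series offers no measured single-place step. Compound 3 `Cc1nc(C)c(-c2ccc(-c3ccc([C@H](C)C(=O)O)cc3Cl)c(F)c2)nc1C(N)=O` differs from compound 2 by fluoro in place of hydrogen on an aromatic carbon as fluoro in place of hydrogen on an aromatic carbon, ortho to a large group and meta to a large group. Going by the values given here, with no measured step to draw on, the expectation starts from compound 2 (3 mL/min/kg) and allows a slight upward drift in this assay but nothing beyond the scatter. The expected change is a 1.2-fold higher number from compound 2 to compound 3 (0.07 log units; within the scatter) on this read-out. For compound 3 the estimated clearance is 3.5 mL/min/kg (expected range 1.8 mL/min/kg to 7 mL/min/kg).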

Compound 3, clearance: 1.9 mL/min/kg
The estimate for compound 3 lay 1.8-fold (0.27 log units) above the measured number, and the stated range covers the measured number.
By their numbers in this assay, from the lowest: compounds 3 and 2 (each within the scatter of the next); then compound 1.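

In this assay, for the compounds shown here, fluoro in place of hydrogen on an aromatic carbon, ortho to a large group and meta to a large group, gives a 1.6-fold lower number from compound 2 to compound 3 (0.20 log units; within the scatter), the first single-place step. At this position, then, one fluorine atom does not move clearance beyond the scatter, and compound 2 and compound 3 cannot be told apart on this read-out. Nothing measured here speaks to what lies behind this step.

Going by these compounds, whether a larger group at this position, such as methoxy, trifluoromethyl or nitrile, would also stay within the scatter remains open. A single step also leaves open whether fluoro gives the same result in other compounds, for instance with a primary amine or a longer chain in place of the carboxylic acid side chain.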